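A few compounds are considered here, and "the series" means these few. Any claim that something is new, unique, unknown or untested is made for them only; others in the source may bear on it.

Measured compounds:
- compound 1 `CCCS(=O)(=O)Nc1ccc(F)c(C(=O)c2n[nH]c3ncc(-c4ccc(S(N)(=O)=O)cc4)cc23)c1F`: 5.1%
- compound 2 `CCCS(=O)(=O)Nc1ccc(F)c(C(=O)c2n[nH]c3ncc(-c4ccc(S(=O)(=O)NCC)cc4)cc23)c1F`: 41%
- compound 3 `CCCS(=O)(=O)Nc1ccc(F)c(C(=O)c2n[nH]c3ncc(-c4ccc(C(N)=O)cc4)cc23)c1F`: 4%

In an assay for binding affinity to dual specificity mitogen-activated protein kinase kinase 4 (Homo sapiens), read by KINOMEscan, tested at 10 nM (on this read-out higher numbers stand for a weaker effect at the one concentration tested and lower numbers for a stronger effect), compound 1 stands second highest of the three numbers. Compound 3 sits nearest, and a number 1.1 percentage points lower from compound 1 to compound 3 (within the scatter). Compound 2 lies furthest, and a number 35.9 percentage points higher from compound 1 to compound 2 (beyond the scatter). Compound 4 `CS(=O)(=O)Nc1ccc(F)c(C(=O)c2n[nH]c3ncc(-c4ccc(S(N)(=O)=O)cc4)cc23)c1F` is not yet measured. It differs from compound 1 in one place: hydrogen in place of ethyl on a saturated chain carbon bound to a sulfonyl sulfur. Going by the values given here, none of the measured steps touches this place; all of them alter the group on the aromatic carbon at the far end of the molecule, so they give no direct guide. Among the compounds with values here, with no bearing step and a small change in chain length, the expected step from compound 1 to compound 4 is a number 2.9 percentage points higher from compound 1 to compound 4 (within the scatter), which is a change of no clear size beyond the scatter. Compound 4 is therefore estimated at 8%, within a range of 2% to 35%.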

Compound 4, a percentage reported as activity, at one concentration (the size of the read-out at that concentration, not a potency): 12%
For compound 4 the middle estimate is 4 percentage points below the measured one; the measured number falls inside the stated range.
By their numbers in this assay, from the lowest: compounds 3, 1 and 4 (each within the scatter of the next); then compound 2.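

This is the first change shown at this place: with propyl cut back to methyl on the sulfonyl group, this assay gives a number 6.9 percentage points higher from compound 1 to compound 4 (within the scatter). The propyl chain can therefore be shortened to methyl here, with the sulfamoyl group held fixed, without a change that stands clear of the scatter on this read-out. No measured evidence is available to explain this result. From the compounds shown here alone, whether a longer chain such as butyl, or a ring such as cyclopropyl, would do the same stays open. So does whether methyl behaves alike when carbamoyl replaces sulfamoyl.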